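The source may report more compounds than this note shows. Statements on the series, on what has been measured and on what is new or still open speak of the compounds shown alone.

Measured in an ADME assay on S9 fraction from liver (Homo sapiens) for metabolic stability, with a stated time of 1 h; on this read-out lower numbers stand for a less stable compound and higher numbers for a more stable compound:

Compound 1 `N#Cc1cnc(NCc2cnccc2C(F)(F)F)cc1N[C@H]1CC[C@H](O)CC1` gives 30%
Compound 2 `CO[C@H]1CC[C@@H](Nc2cc(NCc3cnccc3C(F)(F)F)ncc2C#N)CC1` gives 19%
Compound 3 `CO[C@H]1CC[C@@H](CNc2cc(NCc3cnccc3C(F)(F)F)ncc2C#N)CC1` gives 4%

Compound 2 holds the middle place among these three numbers, below compound 1 and above compound 3. The two steps that touch it are a number 11 percentage points lower from compound 1 to compound 2 (beyond the scatter) and a number 15 percentage points lower from compound 2 to compound 3 (beyond the scatter), and both are modest.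

Compound 4 `N#Cc1cnc(NCc2cnccc2C(F)(F)F)cc1N[C@H]1CC[C@@H](c2nc[nH]n2)CC1` has not yet been measured. It departs from compound 2 at one place: 1H-1,2,4-triazol-3-yl in place of methoxy on a saturated ring carbon. In words, this is 1H-1,2,4-triazol-3-yl in place of methoxy on a saturated ring carbon. Among the measured compounds shown here, no measured compound carries this group, so no step shows the change directly.

For the measured compounds named here, the closest evidence is the one measured exchange involving methoxy on that ring carbon, a number 11 percentage points lower from compound 1 to compound 2 (beyond the scatter), which read in reverse points upward. The steps of a number 26 percentage points lower from compound 1 to compound 3 (beyond the scatter) and a number 15 percentage points lower from compound 2 to compound 3 (beyond the scatter) involve (4-methoxycyclohexyl)methyl and bear on the change only by showing the usual size of steps in this small set. A modest rise in this assay is therefore expected, though this rests on thin evidence. The expected step is a number 13 percentage points higher from compound 2 to compound 4 (beyond the scatter) as an estimate. For compound 4 the estimated value is 32% with an expected range from 10% to 60% as its ends.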

Compound 4, percent of the compound remaining: 13%
Estimate against measurement, compound 4: 19 percentage points above; low and high end bracket the measured number.
By their numbers in this assay, from the lowest: compounds 3, 4 and 2 (each within the scatter of the next, the first and the last beyond it); then compound 1.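

In this assay the exchange of methoxy for 1H-1,2,4-triazol-3-yl on the saturated ring carbon gives a number 6 percentage points lower from compound 2 to compound 4 (within the scatter) and so shows that this carbon can carry a group of 5 heavy atoms, with a five-membered aromatic ring and a hydrogen-bond donor, without a step beyond the scatter on this read-out. The earlier compounds had shown only the exchange between hydroxy and methoxy at this place, and the new result adds that the 1H-1,2,4-triazol-3-yl group does not reach the printed value of the hydroxy compound, since compound 4 gives 13% while compound 1 gives 30% in this assay on the same core. No measurement at hand offers an explanation for this outcome.

On these data alone, whether an amine, a carboxylic acid or a tetrazole on the same saturated ring carbon would read nearer to compound 1 or nearer to compound 4 remains open. Also open, as far as these compounds go, is whether the 1H-1,2,4-triazol-3-yl group would give a similar step on the (4-methoxycyclohexyl)methyl side chain of compound 3, where the chain carries one more carbon.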